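This account rests on a few compounds, and the source may have more. Where it says the series, first, only, none or still open, it means among the compounds named here.

Working notes on the series, read in an ADME assay on BaF3 cells (Mus musculus) for antiproliferative activity, read by CCK-8 assay, with a stated time of 72 h; a higher number here means a weaker inhibitor of growth, a lower number a stronger inhibitor of growth. Compound 1 `O=C(CCSc1ccc2c(/C=C/c3ccccn3)n[nH]c2c1)Nc1ccccc1` gives 690 nM, compound 2 `COc1cccc(NC(=O)CCSc2ccc3c(/C=C/c4ccccn4)n[nH]c3c2)c1` gives 3840 nM, and compound 3 `O=C(CCSc1ccc2c(/C=C/c3ccccn3)n[nH]c2c1)Nc1cccc(C(F)(F)F)c1` gives 2300 nM. Compound 3 stands level with compound 2 within the scatter, and both have higher numbers than compound 1, the strongest inhibitor of growth among the three.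

The next compound is compound 4 `CN1CCN(c2cccc(NC(=O)CCSc3ccc4c(/C=C/c5ccccn5)n[nH]c4c3)c2)CC1`. The change is 4-methylpiperazin-1-yl in place of trifluoromethyl on an aromatic carbon, meta to a large group.

Among the measured compounds shown here, three measured steps bear on this change. Replacing hydrogen gave modest losses in both cases: a 5.6-fold higher number from compound 1 to compound 2 (0.75 log units; beyond the scatter) with methoxy and a 3.3-fold higher number from compound 1 to compound 3 (0.52 log units; beyond the scatter) with trifluoromethyl. Exchanging one group for the other gave a 1.7-fold lower number from compound 2 to compound 3 (0.22 log units; within the scatter), which does not separate them. For the measured compounds named here, no measured compound carries 4-methylpiperazin-1-yl, so the evidence is indirect and the range stays wide. On the basis of that exchange, no step beyond the scatter is expected in this assay. The expected step is a 1.5-fold lower number from compound 3 to compound 4 (0.19 log units; within the scatter). For compound 4 the estimated value is 1500 nM, with an expected range of 400 nM to 5000 nM.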

Compound 4, concentration for 50% growth inhibition: > 10000 nM
Compound 4: no number, only a limit; the forecaster's own chance of this, stated with the estimate: 3%; middle value at least 6.6-fold (0.82 log units) away from the limit.
By their numbers in this assay, from the lowest: compound 1; then compounds 3 and 2 (each within the scatter of the next). At a limit, above all of these: compound 4.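

In this assay compound 4 gives no number, only a limit of the assay: the limit of > 10000 nM in this assay, at which 1 of the 4 values shown sits.

Methoxy and trifluoromethyl could not be separated at this position, meta to a large group, but 4-methylpiperazin-1-yl separates from both, with an at least 4.3-fold higher number from compound 3 to compound 4 (0.63 log units; beyond the scatter) and an at least 2.6-fold higher number from compound 2 to compound 4 (0.41 log units; beyond the scatter). Going by these compounds, with an at least 14-fold higher number from compound 1 to compound 4 (1.16 log units; beyond the scatter), all three groups placed here now give higher numbers than hydrogen, and this change gives the largest step seen at this position, although its true size remains unknown.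

The compounds shown leave open whether the step belongs to the six-membered ring of 4-methylpiperazin-1-yl, to its methyl group or to the amine nitrogens it carries. A morpholine, an unsubstituted piperazine or an open-chain dimethylamino group on the same aromatic carbon would help to separate these possibilities, and a small group such as fluorine would show whether any substituent here can match hydrogen.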